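A few compounds are considered here, and "the series" means these few. Any claim that something is new, unique, unknown or untested is made for them only; others in the source may bear on it.

Series read in a functional assay on MGC-803 cells (Homo sapiens) for antiproliferative activity, read by CCK-8 assay, with a stated time of 72 h, tested at 8 uM; on this read-out lower numbers stand for a weaker effect and higher numbers for a stronger effect at the one concentration tested:

- compound 1 `CC1CCCCN1C(=S)SCc1ccc(C(=O)Nc2ccccc2N)cc1`: 86.9%
- compound 2 `CCN(Cc1ccncc1)C(=S)SCc1ccc(C(=O)Nc2ccccc2N)cc1`: 85.2%
- compound 3 `CN(C(=S)SCc1ccc(C(=O)Nc2ccccc2N)cc1)c1cccnc1`: 82.5%

Compound 3 holds the lowest of the three numbers, but the gaps to it, a number 4.4 percentage points lower from compound 1 to compound 3 (within the scatter) and a number 2.7 percentage points lower from compound 2 to compound 3 (within the scatter), are within the scatter, so the three compounds are not separable.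

Compound 4 `Nc1ccccc1NC(=O)c1ccc(CSC(=S)N2CCCC2)cc1` differs from compound 3 by pyrrolidin-1-yl in place of methyl(pyridin-3-yl)amino on a thiocarbonyl carbon. Every measured step changes the same substituent on the thiocarbonyl carbon: a number 1.7 percentage points lower from compound 1 to compound 2 (within the scatter), a number 4.4 percentage points lower from compound 1 to compound 3 (within the scatter), a number 2.7 percentage points lower from compound 2 to compound 3 (within the scatter), none beyond the scatter. Compound 1, carrying 2-methylpiperidin-1-yl on that carbon, gives 86.9%. The step to compound 4 is therefore expected to stay within the scatter, a number 2.5 percentage points higher from compound 3 to compound 4 (within the scatter). Compound 4 is estimated at 85%, between 76% and 92%.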

Compound 4, a percentage reported as inhibition, at one concentration (the size of the read-out at that concentration, not a potency): 83.4%
The estimate for compound 4 lay 1.6 percentage points above the measured number; the measured number falls inside the stated range.
By their numbers in this assay, from the lowest: compounds 3, 4, 2 and 1 (each within the scatter of the next).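

In this assay, pyrrolidin-1-yl on the thiocarbonyl carbon gives no separation from the larger groups: a number 0.9 percentage points higher from compound 3 to compound 4 (within the scatter), a number 1.8 percentage points lower from compound 2 to compound 4 (within the scatter) and a number 3.5 percentage points lower from compound 1 to compound 4 (within the scatter). Compound 4 thus shows that this position holds a read-out of this size without a six-membered ring or the hydrogen-bond acceptor of the pyridine ring. No measurement available here explains this result.

On these data alone, whether a carboxylic acid or a longer alkyl chain on this carbon would move the number beyond the scatter stays open. Readings at a single concentration also leave any potency differences among these compounds unresolved.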